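The compounds below may be only part of what the source reports. "The series", "measured", "known", "first", "only" and "open" are said of these compounds alone.

Three compounds built on one shared core are followed in an ADME assay on microsomes from liver (Canis lupus familiaris) for metabolic stability; a higher number here means that the compound lasts longer, a lower number that the compound disappears faster. Compound 1 `Cc1cc(C(=O)Nc2ccc(F)cn2)ccc1N(CCN1CCCC1)C(=O)Nc1ccc(Cl)cc1` and compound 2 `Cc1cc(C(=O)Nc2ccc(Cl)cc2)ccc1N(CCN1CCCC1=O)C(=O)Nc1ccc(Cl)cc1` have been measured; compound 3 `Cc1cc(C(=O)Nc2ccc(F)cn2)ccc1N(CCN1CCCC1=O)C(=O)Nc1ccc(Cl)cc1` has not. In this assay compound 1 gives 0.558 h, while compound 2 gives 0.183 h. For the measured compounds named here, of the two numbers known, compound 2 stands lowest, and its only neighbour, compound 1, lies clearly higher, beyond the usual scatter. Compound 1 and compound 2 differ from each other in two places at once, so their gap cannot be tied to a single change.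

Compound 3 is reached from compound 2 by one alteration: 5-fluoropyridin-2-yl in place of 4-chlorophenyl on an amide-type nitrogen. Compound 3 therefore carries the same amide part as compound 1 but keeps the rest of compound 2. Going by the values given here, no measured pair isolates this change, so the expectation rests on the two values alone. The step is expected to be a moderate rise, a 1.6-fold higher number from compound 2 to compound 3 (0.21 log units; within the scatter), in this assay, because compound 1 with the same 5-fluoropyridin-2-yl amide gives 0.558 h. Compound 3 is thus estimated at 0.3 h, with a likely range from 0.15 h to 0.6 h.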

Compound 3, half-life: 0.0517 h
Compound 3: the middle estimate sits 5.8-fold (0.76 log units) above what was measured; the measured number lies below the stated range.
By their numbers in this assay, from the lowest: compound 3; then compound 2; then compound 1.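

In this assay, 5-fluoropyridin-2-yl in place of 4-chlorophenyl on the amide-type nitrogen gives a 3.5-fold lower number from compound 2 to compound 3 (0.55 log units; beyond the scatter), so with 2-oxopyrrolidin-1-yl on the chain this swap lowers the number rather than raising it. The change on the chain, 2-oxopyrrolidin-1-yl in place of pyrrolidin-1-yl, can now be read alone and gives an 11-fold lower number from compound 1 to compound 3 (1.03 log units; beyond the scatter), a larger step than the amide swap, which shows that the higher number of compound 1 goes with its pyrrolidin-1-yl and cannot be credited to its 5-fluoropyridin-2-yl amide. Nothing at hand explains why either change moves the half-life in this direction.

The compounds shown leave open whether the amide swap would lower the number to a similar extent on a compound carrying pyrrolidin-1-yl on the chain, since both of its steps here come from just three compounds. They also leave open how a morpholine ring on the same saturated chain carbon, or a 4-fluorophenyl on the amide-type nitrogen, would compare with the groups seen so far.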